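Same atoms, same bonds: only a drawn stereocentre differs

A few compounds are considered here, and "the series" means these few. Any claim that something is new, unique, unknown or untested is made for them only; others in the source may bear on it.

Measured so far:
compound 1 `OC(CCn1nc2c(Br)c(Br)c(Br)c(Br)c2n1)c1cccc(Br)c1`: 0%
compound 2 `OC(CCn1nc2c(Br)c(Br)c(Br)c(Br)c2n1)c1ccc(F)cc1`: 0%
compound 3 `C[C@@H](O)CCn1nc2c(Br)c(Br)c(Br)c(Br)c2n1`: 0%

All three compounds share one core. In a functional assay on MCF7 cells (Homo sapiens) for antiproliferative activity, read by MTT assay, with a stated time of 48 h, tested at 100 uM (a lower number here means a stronger effect, a higher number a weaker effect of the compound at the concentration tested), compound 1 gives 0%, and the step of no change at the digits printed from compound 1 to compound 2 (within the scatter) shows that putting 4-fluorophenyl in place of 3-bromophenyl leaves the read-out unmoved. Compound 3 stands level with compounds 1 and 2 in this assay. Compound 4 `CC(O)CCn1nc2c(Br)c(Br)c(Br)c(Br)c2n1` differs from compound 3 as follows: the two compounds have the same atoms and bonds; at least one stereo element is drawn with a configuration in one of them and without one in the other: 1 of 1 stereo elements differ; a stereocentre at a saturated chain carbon is drawn R in compound 3 and without a configuration in compound 4. Among the compounds with values here, no measured step bears directly on such a change; the only step available, no change at the digits printed from compound 1 to compound 2 (within the scatter), is flat, and all three measured values sit together. The expected step is therefore none beyond the scatter, namely no change at the digits printed from compound 3 to compound 4 (within the scatter). Compound 4 is estimated at 0%, with a range from 0% to 10%.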

Compound 4, a percentage reported as activity, at one concentration (the size of the read-out at that concentration, not a potency): 0%
Beside the measured number, compound 4's estimate shows no gap at the digits printed; low and high end bracket the measured number.
By their numbers in this assay, from the lowest: compounds 1, 2, 3 and 4 (each within the scatter of the next).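

In this assay, drawing the stereocentre at the saturated chain carbon as R or leaving it undefined makes no visible difference, with no change at the digits printed from compound 3 to compound 4 (within the scatter). Within the data shown here, only one thing separates that pair: the fact that one of compounds 3 and 4 is drawn with a defined configuration and the other without, at the place where they differ. Methyl on the same carbon also reads like either aryl group, with no change at the digits printed from compound 2 to compound 4 (within the scatter) and no change at the digits printed from compound 1 to compound 4 (within the scatter), so this position has yet to show any effect from a change. Still open, from the compounds shown here alone, is how the configuration drawn S would read. Also open, going by these compounds, is whether an amine or a carboxylic acid in place of the hydroxyl, or a longer chain, would move the read-out.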